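A few compounds are considered here, and "the series" means these few. Any claim that something is new, unique, unknown or untested is made for them only; others in the source may bear on it.

Compound 2, with structure `COc1ccc(C(=O)Nc2cccc(Cl)c2Cl)cc1OC1CCCC1`, is one of two analogues measured in an assay on isolated protein for inhibition of phosphodiesterase 4A (Sus scrofa); on this read-out lower numbers stand for stronger inhibition and higher numbers for weaker inhibition. In this assay compound 2 reaches only the limit > 200000 nM, so no number is known for it. Its neighbour compound 1, structure `COc1ccc(C(=O)Nc2ccccc2C)cc1OC1CCCC1`, gives 300 nM in this assay. Among the compounds with values here, the one step that bears on the present question is an at least 660-fold higher number from compound 1 to compound 2 (2.82 log units; beyond the scatter), the change of 2-methylphenyl to 2,3-dichlorophenyl on the amide-type nitrogen; that step is tied to the limit described by the limit of > 200000 nM in this assay, at which 1 of the 2 values shown sits, so its true size is unknown beyond being large. Compound 3, structure `COc1ccc(C(=O)Nc2ccccc2O)cc1OC1CCCC1`, has not yet been measured. It differs from compound 2 by 2-hydroxyphenyl in place of 2,3-dichlorophenyl on an amide-type nitrogen. Compound 1 with its small 2-methylphenyl group sits at 300 nM. Compound 2 with the 2,3-dichlorophenyl group reaches only a limit of the assay. A return of a small substituent on that ring is therefore expected to bring the number back down, although a hydroxyl is not a methyl and the recovery may be partial. Compound 3 is therefore expected to show the step of an at least 130-fold lower number from compound 2 to compound 3 (2.12 log units; beyond the scatter) in this assay. Compound 3 is estimated at about 1500 nM, with a range from 150 nM to 30000 nM.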

Compound 3, half-maximal inhibitory concentration: 1300 nM
Compound 3: the middle estimate sits 1.2-fold (0.06 log units) above what was measured, and the stated range covers the measured number.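

In this assay, the result shows that the steep loss seen with the 2,3-dichlorophenyl group on the amide-type nitrogen does not extend to every replacement of the 2-methylphenyl group, since the 2-hydroxyphenyl group gives an at least 150-fold lower number from compound 2 to compound 3 (2.18 log units; beyond the scatter). From the compounds shown here alone, this step starts from a limit of the assay for compound 2 rather than from a number, so its true size remains unknown beyond being large: the limit of > 200000 nM in this assay, at which 1 of the 3 values shown sits. The comparison that can be read as a true number is a 4.3-fold higher number from compound 1 to compound 3 (0.64 log units; beyond the scatter), which gives a first measured ranking on that aromatic carbon, with hydroxy in place of methyl costing far less than the change to 2,3-dichlorophenyl appears to cost.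

The compounds shown cannot tell whether a single chlorine on this ring would carry the whole loss seen with the 2,3-dichlorophenyl group, or whether that loss needs both chlorine atoms. They also leave open how an amine or a methoxy group on the same aromatic carbon would compare with the methyl and hydroxy groups, and so whether the modest step between those two extends to other groups.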